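Swapping the Aryl Arm of Compound 3 for 2-Chlorophenyl

A few compounds are considered here, and "the series" means these few. Any claim that something is new, unique, unknown or untested is made for them only; others in the source may bear on it.

Of the compounds shown here, three built on one shared core have been tested in an ADME assay on MT4 cells (Homo sapiens) for cytotoxicity, read by MTT assay, with a stated time of 5 days; on this read-out lower numbers stand for higher toxicity in this test and higher numbers for lower toxicity in this test. Compound 1 `Cc1cc(C)c(Oc2cc(Nc3ccc(C#N)cc3)ncc2C(=O)NCc2cn(Cc3ccc(F)cc3)nn2)c(C)c1` carries 4-fluorophenyl on a saturated chain carbon bound to an aromatic nitrogen. In this assay compound 1 reaches only a limit, >= 153000 nM, so no number is known for it (the limit of >= 153000 nM in this assay, at which 1 of the 3 values shown sits). Compound 2 `Cc1cc(C)c(Oc2cc(Nc3ccc(C#N)cc3)ncc2C(=O)NCc2cn(CCCO)nn2)c(C)c1`, with 2-hydroxyethyl in that place, gives 25200 nM in this assay. Compound 3 `Cc1cccc(Cn2cc(CNC(=O)c3cnc(Nc4ccc(C#N)cc4)cc3Oc3c(C)cc(C)cc3C)nn2)c1`, with 3-methylphenyl there, gives 114000 nM. For the measured compounds named here, compound 3 therefore stands highest of the two known numbers, with compound 1 sitting at a limit. The measured steps are an at least 6.0-fold lower number from compound 1 to compound 2 (0.78 log units; beyond the scatter), a 4.5-fold higher number from compound 2 to compound 3 (0.66 log units; beyond the scatter) and an at least 1.3-fold lower number from compound 1 to compound 3 (0.12 log units; that floor lies within the scatter).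

Compound 4 `Cc1cc(C)c(Oc2cc(Nc3ccc(C#N)cc3)ncc2C(=O)NCc2cn(Cc3ccccc3Cl)nn2)c(C)c1` has not yet been measured. (2-chlorophenyl in place of 3-methylphenyl on a saturated chain carbon bound to an aromatic nitrogen). Going by the values given here, only one measured step swaps one aryl group for another, an at least 1.3-fold lower number from compound 1 to compound 3 (0.12 log units; that floor lies within the scatter), and that step stays within the scatter; the larger movements both involve the 2-hydroxyethyl compound. A change beyond the scatter is therefore not expected here, and the expected step is a 1.1-fold higher number from compound 3 to compound 4 (0.02 log units; within the scatter). Compound 4 is estimated at 120000 nM, with a likely range from 50000 nM to 250000 nM.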

Compound 4, half-maximal cytotoxic concentration: >= 188000 nM
Compound 4: only a limit was reported (the forecaster's own chance of this, stated with the estimate: 35%); middle value at least 1.5-fold (0.19 log units) away from the limit.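

Compound 4 reaches only a limit in this assay, so no number is known for it: the limit of >= 188000 nM in this assay, at which 1 of the 4 values shown sits. With 2-chlorophenyl in place of 3-methylphenyl on a saturated chain carbon bound to an aromatic nitrogen, the record shows an at least 1.6-fold higher number from compound 3 to compound 4 (0.21 log units; that floor lies within the scatter) and so no firm change at this place, while the swap from 2-hydroxyethyl shows an at least 7.4-fold higher number from compound 2 to compound 4 (0.87 log units; beyond the scatter) and makes 2-chlorophenyl the third aryl arm to stand clear of that hydroxyl-bearing chain. Compound 1 also stands at a limit, and the step between the two limits cannot be read: the limit of >= 153000 nM in this assay, at which 1 of the 4 values shown sits.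

Among the aryl arms only compound 3 has a true number, so how far 4-fluorophenyl, 3-methylphenyl and 2-chlorophenyl really differ from one another remains open. The compounds shown also leave open whether a chain ending in an amine or a carboxylic acid, or a longer chain ending in a hydroxyl, would bring the number on this read-out down as far as 2-hydroxyethyl does.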